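The source may report more compounds than this note shows. Statements on the series, on what has been measured and on what is new or still open speak of the compounds shown alone.

Measured in a functional assay on HCT-15 cells (Homo sapiens) for inhibition; a lower number here means a stronger inhibitor, a higher number a weaker inhibitor:
- Compound 1 `Oc1ccc(-c2cc(-c3ccccc3F)cc(-c3ccccc3O)n2)cc1`: > 50000 nM, a limit of the assay and not a number
- Compound 2 `Oc1cccc(-c2cc(-c3ccccc3F)cc(-c3cccc(O)c3)n2)c1`: 5300 nM
- Compound 3 `Oc1ccc(-c2cc(-c3ccccc3F)cc(-c3cccc(O)c3)n2)cc1`: 5630 nM

In this assay compound 3 gives 5630 nM. For the measured compounds named here, its only neighbour with a true number lies within the scatter: a 1.1-fold higher number from compound 2 to compound 3 (0.03 log units; within the scatter). Compound 1 offers only a limit: the limit of > 50000 nM in this assay, at which 1 of the 3 values shown sits. The step that starts from this limit is much clearer: an at least 8.8-fold lower number from compound 1 to compound 3 (0.94 log units; beyond the scatter). Moving a hydroxyl group around a ring can therefore matter in one case and not in another.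

Compound 4 `Oc1ccc(-c2cc(-c3cccc(C(F)(F)F)c3)cc(-c3cccc(O)c3)n2)cc1` keeps both hydroxyphenyl groups of compound 3. The change lies elsewhere: 3-(trifluoromethyl)phenyl takes the place of 2-fluorophenyl on an aromatic carbon opposite the ring nitrogen, (3-(trifluoromethyl)phenyl in place of 2-fluorophenyl on an aromatic carbon). Both measured steps alter a hydroxyphenyl group, so neither tests this position directly, and the data give no direction for the swap. They offer only a rough sense of size, from a step within the scatter to a far larger one. The starting point for an expectation is therefore compound 3 at 5630 nM, with a wide margin on either side. Going by the values given here, the expected change is small, with no step clearly beyond the scatter: a 1.1-fold lower number from compound 3 to compound 4 (0.05 log units; within the scatter). The estimated value for compound 4 is 5000 nM, with an expected range from 1800 nM to 16000 nM.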

Compound 4, half-maximal inhibitory concentration: 9540 nM
For compound 4 the middle estimate is 1.9-fold (0.28 log units) below the measured one, within the range that was stated.
By their numbers in this assay, from the lowest: compounds 2, 3 and 4 (each within the scatter of the next). At a limit, above all of these: compound 1.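

For the compounds shown here, this is the first step that tests the aromatic carbon opposite the ring nitrogen, and in this assay the swap from 2-fluorophenyl to 3-(trifluoromethyl)phenyl gives a 1.7-fold higher number from compound 3 to compound 4 (0.23 log units; within the scatter). Compound 3 and compound 4 therefore cannot be told apart here, so this position accepts two different fluorine-bearing phenyl groups with no change beyond the usual scatter, although the step changes both the fluorine-bearing group and where it sits on the phenyl ring and cannot separate those two changes. Going by these compounds alone, the only evidence available concerns the assay limit reached by another compound, and it says nothing about this swap at this position.

Going by these compounds, what remains open is whether this tolerance holds for groups of a different kind at the same carbon, such as an amine, a carboxylic acid or a longer chain, since both groups compared here are fluorine-bearing phenyl rings. On these data alone, it is also open whether 3-(trifluoromethyl)phenyl would give the same picture with the hydroxyphenyl groups of compound 1 or compound 2 in place of those of compound 3.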